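Trimming the sulfonyl substituent to methyl on the benzoxazole sulfonamide

The source may report more compounds than this note shows. Statements on the series, on what has been measured and on what is new or still open speak of the compounds shown alone.

Compound 1, `O=S(=O)(Nc1ccc2oc(-c3ccccc3)nc2c1)c1ccccc1Cl`, is one of three related sulfonamides tested in an ADME assay on HEK293 cells (Homo sapiens) for cytotoxicity, read by resazurin assay, with a stated time of 48 h (a higher number here means that more compound is tolerated, a lower number that less compound is tolerated), where compound 1 gives 73000 nM. Compound 3, `COc1ccc(Cl)cc1S(=O)(=O)Nc1ccc(-c2nc3ccccc3o2)cc1`, gives 75000 nM in this assay. Compound 2, `COc1cccc(S(=O)(=O)Nc2ccc(-c3nc4ccccc4o3)cc2)c1`, reaches only the limit of this assay, > 100000 nM, which is a boundary rather than a number. Among the two plain numbers compound 1 stands lowest, and the gap to compound 3 is an at least 1.3-fold lower number from compound 2 to compound 3 (0.12 log units; that floor lies within the scatter) in its own comparison, so compound 1 and compound 3 are indistinguishable within the scatter; the same holds for (the limit of > 100000 nM in this assay, at which 1 of the 3 values shown sits).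

Compound 4, `CS(=O)(=O)Nc1ccc2oc(-c3ccccc3)nc2c1`, differs from compound 1 by methyl in place of 2-chlorophenyl on a sulfonyl sulfur. Among the compounds with values here, the one measured step, an at least 1.3-fold lower number from compound 2 to compound 3 (0.12 log units; that floor lies within the scatter), swaps one aryl on the sulfonyl sulfur for another and stays within the scatter; no measured step removes the aryl altogether. The expected step is therefore small, a 1.2-fold higher number from compound 1 to compound 4 (0.09 log units; within the scatter), with a lean toward a higher number. Compound 4 is estimated at 90000 nM, between 40000 nM and 200000 nM.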

Compound 4, half-maximal cytotoxic concentration: > 100000 nM
Compound 4 ended at the assay's limit; the forecaster's own chance of this, stated with the estimate: 40%; middle value at least 1.1-fold (0.04 log units) away from the limit.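

The earlier step only exchanged one aryl on the sulfonyl sulfur for another, whereas here the aryl ring leaves altogether and the number in this assay does not fall, the change reading as an at least 1.3-fold higher number from compound 1 to compound 4 (0.13 log units; that floor lies within the scatter). Compound 4 gives > 100000 nM, which is a limit of the assay and not a number. A sulfonyl sulfur carrying only methyl is therefore tolerated as far as this read-out can follow, and the values now gather at the top of its range: the limit of > 100000 nM in this assay, at which 2 of the 4 values shown sit.

On these data alone, only the floor of this step can be read, and its real size stays open. Also open, as far as these compounds go, is how a longer chain such as propyl, an amine or a carboxylic acid on the sulfonyl sulfur would read in this assay.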